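From 2-Chlorobenzyl to 3-Chlorobenzyl: An Expected Step

A few compounds are considered here, and "the series" means these few. Any claim that something is new, unique, unknown or untested is made for them only; others in the source may bear on it.

Compound 1 `COc1ccc(C2N=C(SCc3ccccc3Cl)NC(C)=C2C(=O)Nc2ccc(F)cc2)cc1OC` and compound 2 `COc1ccc(C2N=C(SCc3cccc(Cl)c3)NC(C)=C2C(=O)Nc2ccc(F)cc2)cc1OC` share one core and differ in a single place: 3-chlorophenyl in place of 2-chlorophenyl on a saturated chain carbon bound to a sulfur. In a functional assay on the whole organism (artery, strain albino) with Rattus norvegicus as the target, with a stated time of 30 min, at a dose of 10 mg/kg by the oral route (a lower number here means less inhibition, a higher number more inhibition at the dose given (going by the name of the read-out)), compound 1 gives 6.2% and compound 2 gives 5.2%, so that a number 1 percentage points lower from compound 1 to compound 2 (within the scatter). Compound 3 `CC1=C(C(=O)Nc2ccc([N+](=O)[O-])cc2)C(c2cccc([N+](=O)[O-])c2)N=C(SCc2ccccc2Cl)N1` carries the same (2-chlorobenzyl)sulfanyl group on a different core; how the core of compound 3 differs from that of compound 1 is not broken down here. In this assay compound 3 gives 3.6%, a number within the scatter of both other values. Compound 4 `CC1=C(C(=O)Nc2ccc([N+](=O)[O-])cc2)C(c2cccc([N+](=O)[O-])c2)N=C(SCc2cccc(Cl)c2)N1` has not yet been measured; it differs from compound 3 by the same change, (3-chlorophenyl in place of 2-chlorophenyl on a saturated chain carbon bound to a sulfur), at the place described in the same words. Because the earlier step of the same change was a number 1 percentage points lower from compound 1 to compound 2 (within the scatter), compound 4 is expected to stay close to compound 3 in this assay, with an estimated step of a number 0.6 percentage points lower from compound 3 to compound 4 (within the scatter). The estimate for compound 4 in this assay is therefore 3%, expected to lie between 0% and 12%.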

Compound 4, a percentage reported as inhibition, in the whole organism at one dose (the size of the read-out at that dose, not a potency): 4.1%
Compound 4: middle estimate off by 1.1 percentage points, on the low side, within the range that was stated.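

In this assay, the change from 2-chlorophenyl to 3-chlorophenyl on the core of compound 3 gives a number 0.5 percentage points higher from compound 3 to compound 4 (within the scatter). Set beside the same change on the other core, this step shows no difference that can be told apart from the scatter: the same change on two cores in this assay, a number 1 percentage points lower (within the scatter) from compound 1 to compound 2 and a number 0.5 percentage points higher (within the scatter) from compound 3 to compound 4, 1.5 percentage points apart, within the scatter of two such steps. This shows only that, on these two cores and at this single dose, the change leaves the read-out within the scatter, and it does not show that the change would behave the same way on any further core, at another dose, or that the two cores respond identically in a way smaller steps could reveal.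

The compounds shown leave open whether anything other than a chlorine on the phenyl ring would move the read-out beyond the scatter, for example an amine or a carboxylic acid in its place. They also leave open what a longer chain in place of the benzyl group on the sulfur would do on either core.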